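A few compounds are considered here, and "the series" means these few. Any claim that something is new, unique, unknown or untested is made for them only; others in the source may bear on it.

Measured so far in a physicochemical assay for solubility, measured as kinetic solubility; on this read-out lower numbers stand for lower solubility and higher numbers for higher solubility

- compound 1 `CS(=O)(=O)c1cccc(CNC(=O)c2cc(C(F)(F)F)ccc2Sc2ccccc2)c1` gives 34000 nM
- compound 2 `CS(=O)(=O)c1cccc(CNC(=O)c2cc(C(F)(F)F)ccc2Oc2ccccc2)c1` gives 23000 nM
- compound 3 `CS(=O)(=O)c1cccc([C@H](CO)NC(=O)c2cc(C(F)(F)F)ccc2Oc2ccccc2)c1` gives 11000 nM

Compound 2 shares the upper end of these three numbers. On one side lies a 1.5-fold lower number from compound 1 to compound 2 (0.17 log units; within the scatter), and on the other lies a 2.1-fold lower number from compound 2 to compound 3 (0.32 log units; beyond the scatter).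

Compound 4 `CS(=O)(=O)c1cccc(CNC(=O)c2cc(S(F)(F)(F)(F)F)ccc2Oc2ccccc2)c1` keeps all of compound 2 except one group: a group of 6 heavy atoms (5 fluorine, 1 sulfur; no ring) in place of a group of 4 heavy atoms (1 carbon, 3 fluorine; no ring), on an aromatic carbon. The new group sits para to a phenoxy group, where the trifluoromethyl stood.

For the measured compounds named here, no measured step changes this group, so neither step bears on it directly. Both were made at other places on the molecule, and they serve only as a guide to how far a single change has moved the numbers in this short series. The data give no direct read on direction. Going by the values given here, the working expectation is a small fall, with the size guided by a 2.1-fold lower number from compound 2 to compound 3 (0.32 log units; beyond the scatter), the only step so far beyond the scatter. From the compounds shown here alone, a result on the other side of compound 2 remains open.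

The expected change is a 1.5-fold lower number from compound 2 to compound 4 (0.19 log units; within the scatter), an estimate that may not clear the scatter.

For compound 4 the estimated value in this assay is 15000 nM, with an expected range from 6000 nM to 32000 nM.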

Compound 4, solubility: 7000 nM
Compound 4: middle estimate off by 2.1-fold (0.33 log units), on the high side; the range from low to high includes it.
By their numbers in this assay, from the lowest: compounds 4 and 3 (each within the scatter of the next); then compounds 2 and 1 (each within the scatter of the next).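

Position para to a phenoxy group, read in this assay: replacing trifluoromethyl with the group of 6 heavy atoms (5 fluorine, 1 sulfur) gives a 3.3-fold lower number from compound 2 to compound 4 (0.52 log units; beyond the scatter) and so shows that this position is not silent to change. For the compounds shown here, the earlier steps came from other places on the molecule, so this is the first direct read here, and it points towards a lower number for this exchange on the core of compound 2. Nothing available accounts for the direction or size of this step.

From the compounds shown here alone, it remains open whether other groups at this position, such as a chlorine atom, a nitrile, an amine or a carboxylic acid, would also lower the number or would raise it instead. Going by these compounds alone, it is also open whether the same exchange would give a similar step on the core of compound 1, with its phenylsulfanyl group, or on the core of compound 3, with its hydroxymethyl group, as the step so far rests on the single pair of compound 2 and compound 4.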